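Bromine position on the benzyl group of compound 2

The compounds below may be only part of what the source reports. "The series", "measured", "known", "first", "only" and "open" are said of these compounds alone.

Compound 2, `CCCn1c(=O)[nH]c2nc(-c3ccc(S(=O)(=O)N4CCN(Cc5cccc(Br)c5)CC4)cc3)[nH]c2c1=O`, was tested in an assay on CHO cells for displacement of a labelled ligand from adenosine receptor A3 (Homo sapiens), read by scintillation counting, with a stated time of 45 min, in the presence of a further agent that is not named here; on this read-out lower numbers stand for stronger inhibition and higher numbers for weaker inhibition. In this assay compound 2 gives > 1000 nM, which is a limit of the assay and not a number. Compound 1, `CCCn1c(=O)[nH]c2nc(-c3ccc(S(=O)(=O)N(C)C)cc3)[nH]c2c1=O`, gives 1220 nM in this assay. Compound 3, `CCCn1c(=O)c2[nH]c(-c3ccc(S(=O)(=O)N4CCN(c5ccc(Cl)cc5)CC4)cc3)nc2n(CC)c1=O`, gives > 1000 nM in this assay, again a limit rather than a number. Among the three values shown, compound 2 therefore sits at the limit of > 1000 nM in this assay, at which 2 of the 3 values shown sit, and only compound 1 comes with a measured number. Compound 4, `CCCn1c(=O)[nH]c2nc(-c3ccc(S(=O)(=O)N4CCN(Cc5ccc(Br)cc5)CC4)cc3)[nH]c2c1=O`, has not yet been measured in this assay. It differs from compound 2 in one place: 4-bromophenyl in place of 3-bromophenyl on a saturated chain carbon bound to an amine nitrogen in a ring. The two compounds have the same atoms, joined differently. No step between measured compounds is available here, so the size of such a change cannot be read from a shown pair. Because compound 2 gives only a limit, > 1000 nM, the expectation for compound 4 rests on that limit alone. The expected step is a step that the limit leaves unreadable from compound 2 to compound 4, which is none beyond the scatter. Compound 4 is estimated at 2000 nM, with a range from 900 nM to 5000 nM, and most likely the assay will again report only a limit.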

Compound 4, inhibition constant: > 1000 nM
Compound 4 gave a limit, no number; the forecaster's own chance of this, stated with the estimate: 75%; the middle value does not contradict the limit.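

In this assay compound 2 and compound 4 are both reported only as a limit of the assay, not as a number, so no step can be read between them: the limit of > 1000 nM in this assay, at which 3 of the 4 values shown sit. The compounds shown leave open whether 4-bromophenyl in place of 3-bromophenyl changes the inhibition constant in this assay at all.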